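Cyclohexyl in place of cyclopentyl on sulfur: working notes

The compounds below may be only part of what the source reports. "The series", "measured", "known", "first", "only" and "open" are said of these compounds alone.

Measured in a functional assay on MT4 cells (Homo sapiens) for cytotoxicity; a lower number here means that less compound is tolerated, a higher number that more compound is tolerated:
Compound 1 `CCC(c1ccccc1)c1cc(O)nc(SC2CCCC2)n1`: 50000 nM
Compound 2 `CCC(c1cc(O)nc(SC(C)C)n1)c1c(Cl)cccc1Cl`: > 200000 nM (a limit of the assay, not a number)
Compound 3 `CCC(c1cc(O)nc(SC2CCCC2)n1)c1c(Cl)cccc1Cl`: 70000 nM

Compound 3 stands level with its nearest neighbour on the numbers, the step being a 1.4-fold higher number from compound 1 to compound 3 (0.15 log units; within the scatter). That step concerns the other substituent and says little about the sulfur.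

Compound 4 `CCC(c1cc(O)nc(SC2CCCCC2)n1)c1c(Cl)cccc1Cl` carries cyclohexyl in place of cyclopentyl on a sulfur. Going by the values given here, the one measured step at this place is an at least 2.8-fold lower number from compound 2 to compound 3 (0.45 log units; beyond the scatter), and its full size is unknown. On that single step, a small move in the same direction in this assay is a reasonable expectation, though probably not one that clears the scatter. The estimated step is a 1.4-fold lower number from compound 3 to compound 4 (0.15 log units; within the scatter). For compound 4 the expected value is 50000 nM, with an estimated range of 20000 nM to 130000 nM.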

Compound 4, half-maximal cytotoxic concentration: 200000 nM
Compound 4: the middle estimate sits 4.0-fold (0.60 log units) below what was measured, and the stated range ends below it.
By their numbers in this assay, from the lowest: compounds 1 and 3 (each within the scatter of the next); then compound 4.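

In this assay the sulfur position does not move in one direction: cyclohexyl in place of cyclopentyl gives a 2.9-fold higher number from compound 3 to compound 4 (0.46 log units; beyond the scatter), the opposite direction to an at least 2.8-fold lower number from compound 2 to compound 3 (0.45 log units; beyond the scatter), and cyclohexyl in place of isopropyl gives a number no higher from compound 2 to compound 4 (the limit leaves the size open). Among the three compounds carrying 2,6-dichlorophenyl, the one with cyclopentyl on the sulfur, compound 3, therefore has the lowest number, with both isopropyl and cyclohexyl standing higher. The size of the comparison of cyclohexyl with isopropyl on a sulfur cannot be read, the value of compound 2 being a limit: the limit of > 200000 nM in this assay, at which 1 of the 4 values shown sits.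

Compound 1 is the only phenyl compound shown, so it remains open whether the same turn at cyclopentyl holds without the two chlorines. Also open, from the compounds shown here alone, is where a butyl chain or a piperidine ring on the sulfur would stand in this assay.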